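A few compounds are considered here, and "the series" means these few. Any claim that something is new, unique, unknown or untested is made for them only; others in the source may bear on it.

Compound 1 (`CC(C)C(=O)N(Cc1ccc(Cl)cc1Cl)[C@H]1CCNC1`) is built on a shared core in which an aromatic ring carrying two chloro groups is joined through a nitrogen to a saturated ring. In an assay on HEK293 cells for inhibition of sodium-dependent dopamine transporter (Homo sapiens), read by scintillation counting (a lower number here means a stronger inhibitor, a higher number a weaker inhibitor), compound 1 gives > 40000 nM; this is a limit of the assay, not a measured number. Compound 2 (`O=C(C1CC1)N(Cc1ccc(Cl)cc1Cl)[C@H]1CCNC1`) belongs to the same series, but in this assay compound 2 gives "not determined" (no result reported), so no result exists for it. Where compound 1 stands is therefore known only through (the limit of > 40000 nM in this assay, at which 1 of the 2 values shown sits); it sits at that limit, and the one other entry offers no single number to set beside it.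

Compound 3 (`CC(C)C(=O)N(Cc1ccc(Cl)c(Cl)c1Cl)[C@H]1CCNC1`) differs from compound 1 by chloro in place of hydrogen on an aromatic carbon, ortho to two chloro groups and meta to a large group. Within the data shown here, no pair of measured compounds shows how such a change plays out here. In this assay the expected step is a number no higher from compound 1 to compound 3 (the limit leaves the size open), none beyond the usual scatter. Compound 3 is estimated at 40000 nM, within a range from 10000 nM to 150000 nM.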

Compound 3, half-maximal inhibitory concentration in the sodium-dependent dopamine transporter assay: 5870 nM
Compound 3: the middle estimate sits 6.8-fold (0.83 log units) above what was measured; the measured number lies below the stated range.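

In the sodium-dependent dopamine transporter assay, the added chloro group, on the aromatic carbon ortho to two chloro groups and meta to a large group, brings an at least 6.8-fold lower number from compound 1 to compound 3 (0.83 log units; beyond the scatter), so this position can respond to substitution and the series can give a measured number rather than only a limit. For compound 1 the starting point is a limit of the assay and not a number, so the step has a known minimum but no known full size: the limit of > 40000 nM in the sodium-dependent dopamine transporter assay, at which 1 of the 3 values shown sits. In a physicochemical assay for lipophilicity, at pH 7.4 (on this read-out lower numbers stand for lower lipophilicity and higher numbers for higher lipophilicity), compound 1 gives 0.8 and compound 3 gives 1.3. Lipophilicity also rises with the same change, as read in the physicochemical assay: the measured distribution coefficient of compound 1, 0.8, and of compound 3, 1.3, a number 0.50 log units higher (beyond the scatter)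

This single pair cannot show whether the lower number in the sodium-dependent dopamine transporter assay follows the rise in lipophilicity or depends on the chloro group itself, and compound 2 offers no result to set beside it. As far as these compounds go, it also remains open whether a different group on the same aromatic carbon, such as a methyl group, a methoxy group or a nitrile, would lower the number as well, or whether a chloro group is needed there.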